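Fluoro replacing hydrogen on the core of compound 1

This account rests on a few compounds, and the source may have more. Where it says the series, first, only, none or still open, it means among the compounds named here.

- compound 1 `CC(C)COc1ncc(-c2cn(C)c3cc(C(=O)NS(C)(=O)=O)ccc23)cc1Cl`: 216 nm/s
- compound 2 `CC(C)Cc1ccc(-c2cn(C)c3cc(C(=O)NS(C)(=O)=O)ccc23)cc1`: "not determined" (no result reported)

Within the data shown here, in an ADME assay for permeability, using PAMPA, at pH 7.4 (on this read-out lower numbers stand for lower permeability and higher numbers for higher permeability), compound 1 gives 216 nm/s, the only number so far, so it has no measured comparison. Compound 2 has no reported result. Compound 3 `CC(C)COc1ncc(-c2cn(C)c3cc(C(=O)NS(C)(=O)=O)c(F)cc23)cc1Cl` differs from compound 1 by fluoro in place of hydrogen on an aromatic carbon, ortho to a (methylsulfonyl)carbamoyl group. Among the measured compounds shown here, no measured pair shows the size of such a change. The expected 1.1-fold lower number from compound 1 to compound 3 (0.03 log units; within the scatter) in this assay is therefore none beyond the scatter. For compound 3 the estimated value is 200 nm/s, with an expected range of 95 nm/s to 420 nm/s.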

Compound 3, apparent permeability: 205 nm/s
The estimate for compound 3 lay 1.0-fold (0.01 log units) below the measured number; low and high end bracket the measured number.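

Fluoro in place of hydrogen on an aromatic carbon, ortho to a (methylsulfonyl)carbamoyl group, gives a 1.1-fold lower number from compound 1 to compound 3 (0.02 log units; within the scatter) in this assay as the first measured step in the series. In this single pair, the read-out does not separate fluoro from hydrogen at this position. No measurement at hand offers an explanation for this result.

Still open, on these data alone, is whether an amine or a methoxy group at this carbon would give a step beyond the scatter. Also open, as far as these compounds go, is whether a carboxylic acid in place of the (methylsulfonyl)carbamoyl group would leave fluoro's step equally small.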